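Aryl swap on the cinnamoyl hydrazide series: cytotoxicity notes

The compounds below may be only part of what the source reports. "The series", "measured", "known", "first", "only" and "open" are said of these compounds alone.

Measured compounds:
compound 1, `COc1cccc(/C=C/C(=O)NNC(=O)c2ccc3c(c2)OCCO3)c1`, 398000 nM
compound 2, `O=C(/C=C/c1ccccc1[N+](=O)[O-])NNC(=O)c1ccc2c(c1)OCCO2`, 257000 nM

In an ADME assay on cells (Macrophage) for cytotoxicity, read by MTT assay, with a stated time of 24 h (on this read-out lower numbers stand for higher toxicity in this test and higher numbers for lower toxicity in this test), compound 1 gives 398000 nM and compound 2 gives 257000 nM. Among the compounds with values here, compound 2 holds the lowest of the two numbers so far, but its only neighbour is compound 1, and the step of a 1.5-fold lower number from compound 1 to compound 2 (0.19 log units; within the scatter) stays within the scatter, so the two values cannot be ordered against each other.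

Compound 3, `Cc1cccc(/C=C/C(=O)NNC(=O)c2ccc3c(c2)OCCO3)c1`, is not yet measured in this assay. Its difference from compound 2: 3-methylphenyl in place of 2-nitrophenyl on a double-bonded chain carbon bound to a double-bonded chain carbon. Within the data shown here, the one measured step that bears on this place is a 1.5-fold lower number from compound 1 to compound 2 (0.19 log units; within the scatter), which swapped a substituted phenyl for another at the same chain carbon and produced no change beyond the scatter. Among the measured compounds shown here, with no larger step at this position to draw on, no movement beyond the scatter is expected from compound 2 to compound 3 either; the estimated step is a 1.3-fold higher number from compound 2 to compound 3 (0.11 log units; within the scatter). Compound 3 is therefore estimated at 330000 nM in this assay, with a range from 150000 nM to 750000 nM that spans both measured values.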

Compound 3, half-maximal cytotoxic concentration: 281000 nM
The estimate for compound 3 lay 1.2-fold (0.07 log units) above the measured number; low and high end bracket the measured number.
By their numbers in this assay, from the lowest: compounds 2, 3 and 1 (each within the scatter of the next).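

In this assay, 3-methylphenyl in place of 2-nitrophenyl on a double-bonded chain carbon bound to a double-bonded chain carbon gives a step that stays within the scatter (a 1.1-fold higher number from compound 2 to compound 3 (0.04 log units; within the scatter)), even though the entering group has 0 hydrogen-bond acceptors against 2 in the group that leaves, and has no double bond outside the aromatic ring. The series now also holds a smaller single-place change, methyl in place of methoxy on an aromatic carbon, and this too stays within the scatter (a 1.4-fold lower number from compound 1 to compound 3 (0.15 log units; within the scatter)), so the three aryl groups shown cannot be ordered in this test and none of the three compounds goes against that reading. No measured data on these compounds offer a reason for this lack of separation.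

The compounds shown leave open whether an amine or a carboxylic acid on the phenyl ring would give a step beyond the scatter, since only methoxy, nitro and methyl groups appear there. Also open, on these data alone, is whether a longer chain in place of the double-bonded carbons, or a change to the shared core, would move the number at all.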